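This account rests on a few compounds, and the source may have more. Where it says the series, first, only, none or still open, it means among the compounds named here.

Measured compounds:
compound 1 `CC(C(=O)NCc1ccc(C(F)(F)F)cc1N1CCCCCCC1)c1ccc(NS(C)(=O)=O)c(F)c1`, 2.8 nM
compound 2 `CC(C(=O)NCc1ccc(C(F)(F)F)cc1N1CCC(c2ccc(F)cc2)CC1)c1ccc(NS(C)(=O)=O)c(F)c1`, 0.9 nM

Among the measured compounds shown here, in an assay on CHO cells for antagonist activity at transient receptor potential cation channel subfamily V member 1 (Homo sapiens), read by FLIPR (a higher number here means a weaker inhibitor, a lower number a stronger inhibitor), compound 1 gives 2.8 nM, the higher of the two numbers measured so far. Compound 2 gives 0.9 nM in this assay, and the gap between the two lies beyond the usual scatter. For the measured compounds named here, no single-change step between measured compounds is recorded, so the two values are all that is known.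

Compound 3 `CC(C(=O)NCc1ccc(C(F)(F)F)cc1N1CCN(c2ccccc2)CC1)c1ccc(NS(C)(=O)=O)c(F)c1` differs from compound 1 in one place: a group of 12 heavy atoms (10 carbon, 2 nitrogen; one six-membered non-aromatic ring with 2 hetero atoms, one six-membered aromatic ring of carbon only) in place of a group of 8 heavy atoms (7 carbon, 1 nitrogen; one eight-membered non-aromatic ring with 1 hetero atom), on an aromatic carbon. The group that enters carries a six-membered aromatic ring on a six-membered non-aromatic ring with two hetero atoms, which brings it nearer to the shape of the group present in compound 2 than to the eight-membered ring of compound 1. Given that compound 2 shows 0.9 nM, a step downward from compound 1 is expected, of moderate size, though a value within the scatter of compound 1 cannot be ruled out. The expected step is a 1.9-fold lower number from compound 1 to compound 3 (0.27 log units; within the scatter). Compound 3 is estimated at 1.5 nM, with a range from 0.5 nM to 5 nM.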

Compound 3, inhibition constant: 2 nM
The estimate for compound 3 lay 1.3-fold (0.12 log units) below the measured number; the range from low to high includes it.
By their numbers in this assay, from the lowest: compound 2; then compounds 3 and 1 (each within the scatter of the next).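

In this assay, placing 4-phenylpiperazin-1-yl on this aromatic carbon instead of the eight-membered ring gives a 1.4-fold lower number from compound 1 to compound 3 (0.15 log units; within the scatter). Among the compounds shown here, this is the first single-change step read at this position, and it shows that a group of two rings, one of them a six-membered aromatic ring of carbon only, and with a second nitrogen, can stand here with the number staying within the scatter of the one-ring group in compound 1. Nothing measured on these compounds accounts for this result.

For the compounds shown here, still open is how the number responds at this position to a much smaller group, such as a dimethylamino group or a bare hydrogen, as the step read here joins only two ring groups of 8 and 12 heavy atoms. Also open, going by these compounds, is whether a fluorine, a methoxy group or a carboxylic acid on the phenyl ring of the 4-phenylpiperazin-1-yl group would move the number beyond the scatter of compound 3.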